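The source may hold more compounds than are shown below. What is called first, only, known or untested is meant among the compounds shown, and "the series" means these compounds.

Compound 1 `Cc1ccc2occ(C3N=C(c4ccccc4)SS3)c(=O)c2c1` is tested in a functional assay on COLO 205 cells (Homo sapiens) for inhibition, read by sulforhodamine B assay, with a stated time of 48 h (on this read-out higher numbers stand for weaker inhibition and lower numbers for stronger inhibition), where compound 1 gives > 100000 nM, which is a limit of the assay rather than a number. Compound 3 `O=c1c(C2N=C(c3ccccc3)SS2)coc2cc(Cl)c(Cl)cc12` likewise gives > 100000 nM in this assay, again a limit. Compound 2 `O=c1c(C(=S)Nc2ccccc2)coc2cc(Cl)ccc12` in this assay gives > 100000 nM, also a limit. Compound 2 thus stands where every measured compound stands, at the limit of > 100000 nM in this assay, at which 3 of the 3 values shown sit. Compound 4 `O=c1c(C(=S)Nc2ccccc2)coc2cc(Cl)c(Cl)cc12` differs from compound 2 by chloro in place of hydrogen on an aromatic carbon. With no change measured between any two of these compounds, no shift beyond the scatter is expected for this replacement, so the step expected is a step that the limit leaves unreadable from compound 2 to compound 4. The value of compound 4 in this assay is estimated at 150000 nM, between 40000 nM and 600000 nM, most likely again reported only as a limit.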

Compound 4, half-maximal inhibitory concentration: > 100000 nM
Compound 4: no number, only a limit; the forecaster's own chance of this, stated with the estimate: 85%; the middle value does not contradict the limit.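

Compound 2 and compound 4 both sit at a limit of the assay rather than at a number, so no step can be read between them: the limit of > 100000 nM in this assay, at which 4 of the 4 values shown sit.

The compounds shown leave open which change to the shared core, if any, would bring a number in this assay rather than a limit.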